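The source may report more compounds than this note shows. Statements on the series, on what has been measured and on what is new or still open speak of the compounds shown alone.

Compound 1 `Cc1cc(Oc2cccc(Cn3nccn3)c2)cc(C)c1Cl` was tested in an ADME assay on NIH3T3 cells (Mus musculus) for cytotoxicity; on this read-out lower numbers stand for an effect already at smaller amounts and higher numbers for an effect only at larger amounts of compound. In this assay compound 1 gives > 100000 nM, which is a limit of the assay and not a number. Compound 2 `Cc1cc(Oc2cccc(Cn3cc4ccccc4n3)c2)cc(C)c1Cl` gives > 100000 nM, which is also a limit. For the measured compounds named here, there is therefore no exact number for compound 1, and no measured step between closely related compounds is available as a guide.

Compound 3 `Cc1nnc(Cc2cccc(Oc3cc(C)c(Cl)c(C)c3)c2)s1` keeps the core of compound 1 and changes one group, with 5-methyl-1,3,4-thiadiazol-2-yl in place of 2H-1,2,3-triazol-2-yl on a saturated chain carbon bound to an aromatic carbon. The group that enters is one atom larger by the count, and it is still a single five-membered aromatic ring without a net charge.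

A step of a number no higher from compound 1 to compound 3 (the limit leaves the size open) is expected in this assay, meaning no change beyond the usual scatter, because of the limit of > 100000 nM in this assay, at which 2 of the 2 values shown sit. The assay may well report only a limit again. For compound 3 the estimated value is 100000 nM, with an expected range from 40000 nM to 200000 nM.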

Compound 3, half-maximal effective concentration: 3800 nM
Beside the measured number, compound 3's estimate is 26-fold (1.42 log units) above it; the measured number lies below the stated range.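

In this assay, replacing 2H-1,2,3-triazol-2-yl with 5-methyl-1,3,4-thiadiazol-2-yl gives an at least 26-fold lower number from compound 1 to compound 3 (1.42 log units; beyond the scatter), so the group held on this saturated chain carbon bound to an aromatic carbon can make a large difference to the read-out. The earlier compounds could not show this, since both gave only a limit of the assay and so offered no exact number, whereas compound 3 gives the first exact value among the compounds shown. The step can be stated only as a minimum because the starting point is a limit and not a number: the limit of > 100000 nM in this assay, at which 2 of the 3 values shown sit.

As far as these compounds go, the change swaps the ring and adds a methyl group in a single step, so it remains open whether the ring, the methyl group or the two together account for the lower number. From the compounds shown here alone, it also remains open how a plain 1,3,4-thiadiazol-2-yl group without the methyl, or a group of another kind such as a carboxylic acid or an amine on the same chain carbon, would read in this assay.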